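The compounds below may be only part of what the source reports. "The series", "measured", "known", "first", "only" and "open" are said of these compounds alone.

Of the compounds shown here, three sharing one core have been tested in a functional assay for agonist activity at G protein-coupled receptor 88 (Homo sapiens), read by HTRF and cAMP accumulation; on this read-out lower numbers stand for an effect already at smaller amounts and higher numbers for an effect only at larger amounts of compound. Compound 1 `CCOc1ccc(-c2ccc(N(C[C@@H](N)[C@@H](C)CC)C(=O)[C@@H]3C[C@H]3c3ccccc3)cc2)cc1` carries an ethyl group on an oxygen of the outer aromatic ring and gives 90 nM. Compound 2 `CC[C@H](C)[C@H](N)CN(C(=O)[C@@H]1C[C@H]1c1ccccc1)c1ccc(-c2ccc(Oc3ccccc3)cc2)cc1` has a phenyl group in that place and gives 94 nM. Compound 3 `CC[C@H](C)[C@H](N)CN(C(=O)[C@@H]1C[C@H]1c1ccccc1)c1ccc(-c2ccc(OC(F)(F)F)cc2)cc1` has a trifluoromethyl group there and gives 170 nM. Compound 3 thus shows the highest number of the three, but each step to it lies within the scatter: a 1.9-fold higher number from compound 1 to compound 3 (0.28 log units; within the scatter) and a 1.8-fold higher number from compound 2 to compound 3 (0.26 log units; within the scatter), just as a 1.0-fold higher number from compound 1 to compound 2 (0.02 log units; within the scatter) does. Swapping what sits on that oxygen has so far left this assay essentially unchanged.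

Compound 4 `CC[C@H](C)[C@H](N)CN(C(=O)[C@@H]1C[C@H]1c1ccccc1)c1ccc(-c2ccc(CCC(=O)OC)cc2)cc1` goes one step further: 2-(methoxycarbonyl)ethyl in place of trifluoromethoxy on an aromatic carbon. This change takes away the oxygen on the ring together with its trifluoromethyl group and puts a chain in their place, so the measured steps, which only exchange groups on the oxygen, bear on it only loosely. They give no sign that this part of the molecule matters much for the read-out, so no shift beyond the scatter is expected, while the larger change widens the uncertainty. Compound 4 is therefore estimated at 150 nM, within a range of 60 nM to 400 nM, which corresponds to an expected step of a 1.1-fold lower number from compound 3 to compound 4 (0.05 log units; within the scatter).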

Compound 4, half-maximal effective concentration: 110 nM
For compound 4 the middle estimate is 1.4-fold (0.13 log units) above the measured one, within the range that was stated.
By their numbers in this assay, from the lowest: compounds 1, 2, 4 and 3 (each within the scatter of the next).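

In this assay every earlier group at this place, para to a large group, hung from an oxygen on the aromatic ring, whereas compound 4 has a carbon chain attached directly to that ring, and the swap gives a 1.5-fold lower number from compound 3 to compound 4 (0.19 log units; within the scatter). The comparisons with the other two groups read the same way, with a 1.2-fold higher number from compound 2 to compound 4 (0.07 log units; within the scatter) and a 1.2-fold higher number from compound 1 to compound 4 (0.09 log units; within the scatter), so the oxygen on the ring is not required for a number in this range, and a chain holding a carbonyl fits in just as well. No measurement shown here gives a reason for this flat result.

From the compounds shown here alone, what remains open is whether any group at this place can move the number in this assay beyond the scatter, since all four compounds so far sit within it of one another. The clearest tests would be the carboxylic acid in place of the methyl ester of compound 4, a primary amine at the end of the chain, a longer chain, or plain hydrogen on the ring.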